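This account rests on a few compounds, and the source may have more. Where it says the series, first, only, none or still open, it means among the compounds named here.

Working notes on the shared core of compound 1 `C[C@@H](O)[C@H]1C(=O)N2C(C(=O)OCOC(=O)C(C)(C)C)=C(S[C@@H]3CN[C@H](C(=O)Nc4cccc(C(=O)OCOC(=O)C(C)(C)C)c4)C3)[C@H](C)[C@H]12`, compound 2 `C[C@@H](O)[C@H]1C(=O)N2C(C(=O)O)=C(S[C@@H]3CN[C@H](C(=O)Nc4cccc(C(=O)OCC(F)(F)F)c4)C3)[C@H](C)[C@H]12` and compound 3 `C[C@@H](O)[C@H]1C(=O)N2C(C(=O)O)=C(S[C@@H]3CN[C@H](C(=O)Nc4cccc(C(=O)OCOC(=O)C(C)(C)C)c4)C3)[C@H](C)[C@H]12`.

In a physicochemical assay for metabolic stability, read by LC-MS, in phosphate buffer, with a stated time of 3 h, at pH 7.4, tested at 50 uM (on this read-out lower numbers stand for a less stable compound and higher numbers for a more stable compound), compound 1 gives > 95%, a limit of the method and not a number. In this assay compound 2 gives > 95%, likewise a limit and not a number. Both values sit at the limit of > 95% in this assay, at which 2 of the 2 values shown sit, so no order between compound 1 and compound 2 can be read from them, and nothing places compound 2 apart from compound 1 on these numbers.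

Compound 3 carries the change (((tert-butyl)carbonyl)oxy in place of trifluoromethyl on a saturated chain carbon bound to an oxygen next to a carbonyl group). Among the measured compounds shown here, no measured step of this kind is available; the single point of orientation is that compound 1, which carries the same (((tert-butyl)carbonyl)oxy)methoxy)carbonyl group, gives > 95%.

The step from compound 2 to compound 3 in this assay is expected to be none beyond the usual scatter, with a number no higher from compound 2 to compound 3 (the limit leaves the size open). Compound 3 is therefore estimated at 95%, within 85% to 100%, most probably again reported as a limit rather than a number.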

Compound 3, percent of the compound remaining: > 95%
Compound 3: only a limit was reported; the forecaster's own chance of this, stated with the estimate: 80%; the middle value lies on the limit itself.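

In this assay, no step can be read from compound 1 to compound 3 or from compound 2 to compound 3, since the values are limits of the method and not numbers: the limit of > 95% in this assay, at which 3 of the 3 values shown sit.

The compounds shown leave open whether either change, going to compound 3 from compound 1 or from compound 2, moves the percent of compound remaining at all.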